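From an open chain to a cyclohexyl ring

This account rests on a few compounds, and the source may have more. Where it says the series, first, only, none or still open, it means among the compounds named here.

Measured so far in an ADME assay on microsomes from liver (Homo sapiens) for metabolic stability; on this read-out lower numbers stand for a less stable compound and higher numbers for a more stable compound:
compound 1 `C/C(CN)=C(/F)CN(C[C@H]1Cc2ccccc2CN1)[C@H]1CCCc2cccnc21`: 97%
compound 2 `C/C(CN(C[C@H]1Cc2ccccc2CN1)[C@H]1CCCc2cccnc21)=C(\F)CN`: 51%
compound 3 `C/C(=C/CN)CN(C[C@H]1Cc2ccccc2CN1)[C@H]1CCCc2cccnc21`: 96%

Compound 3, at 96%, is level with compound 1 within the scatter and far above compound 2. Compound 4 `N[C@H]1CC[C@@H](N(C[C@H]2Cc3ccccc3CN2)[C@H]2CCCc3cccnc32)CC1` replaces the open chain on the amine nitrogen with 4-aminocyclohexyl: a group of 7 heavy atoms (6 carbon, 1 nitrogen; one six-membered non-aromatic ring of carbon only) in place of a group of 6 heavy atoms (5 carbon, 1 nitrogen; no ring), on an amine nitrogen. Going by the values given here, no measured step makes this exact change, so the open-chain swaps are the only guide. They range from a number 1 percentage points lower from compound 1 to compound 3 (within the scatter), within the scatter, to a number 46 percentage points lower from compound 1 to compound 2 (beyond the scatter) and a number 45 percentage points higher from compound 2 to compound 3 (beyond the scatter), both large. Changes to this chain can therefore matter greatly, and a moderate fall in this assay is expected since compound 3 stands at 96% with little room to rise. The expected step is a number 16 percentage points lower from compound 3 to compound 4 (beyond the scatter). For compound 4 the estimate is 80%, with an expected range of 52% to 98%.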

Compound 4, percent of the compound remaining: 86%
For compound 4 the middle estimate is 6 percentage points below the measured one; low and high end bracket the measured number.
By their numbers in this assay, from the lowest: compound 2; then compounds 4, 3 and 1 (each within the scatter of the next, the first and the last beyond it).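

In this assay, a ring can take the place of the open chain on this amine nitrogen: 4-aminocyclohexyl gives a number 10 percentage points lower from compound 3 to compound 4 (within the scatter). The same ring gives a number 11 percentage points lower from compound 1 to compound 4 (beyond the scatter), a modest loss, and a number 35 percentage points higher from compound 2 to compound 4 (beyond the scatter), a large gain. An open chain with a double bond is therefore not required for a high number here, and the ring avoids the low value of the chain in compound 2.

Going by these compounds, whether a piperidin-4-yl ring or a 4-hydroxycyclohexyl group would hold up on this nitrogen remains open. Nothing available explains these differences.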